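The source may report more compounds than this note shows. Statements on the series, on what has been measured and on what is new or still open speak of the compounds shown alone.

Series notes. Compound 1 `O=C(O)CCCSCCN1C(=O)OC[C@@H]1/C=C/[C@@H](O)Cc1ccccc1` is the reference point. In an assay on CHO cells for displacement of a labelled ligand from prostaglandin E2 receptor EP2 subtype (Mus musculus), read by scintillation counting, with a stated time of 60 min (on this read-out higher numbers stand for weaker inhibition and lower numbers for stronger inhibition), compound 1 reaches only the assay limit, recorded as > 10000 nM. Compound 2 `O=C(O)CCCSCCN1C(=O)SC[C@@H]1/C=C/[C@@H](O)Cc1cccc(C(F)(F)F)c1` belongs to the same series. In this assay compound 2 likewise reaches only the limit, recorded as > 10000 nM. Where compound 1 stands cannot be placed more closely than that: both values shown are limits, the limit of > 10000 nM in this assay, at which 2 of the 2 values shown sit, is the whole of what is known, and no step between measured compounds can be drawn from them.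

Compound 3 `O=C(O)CCCSCCN1C(=O)OC[C@@H]1/C=C/[C@@H](O)Cc1cccc(Cl)c1` is not yet measured. It differs from compound 1 by chloro in place of hydrogen on an aromatic carbon. Among the measured compounds shown here, with compound 1 sitting at the limit, no measured step gives a direction or a size for this change. The estimated step that the limit leaves unreadable from compound 1 to compound 3 in this assay is expected to be none beyond the scatter, and a limit rather than a number is again the likelier report. Compound 3 is expected to give about 15000 nM in this assay, with a range from 5000 nM to 50000 nM.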

Compound 3, inhibition constant: > 10000 nM
Compound 3: only a limit was reported; the forecaster's own chance of this, stated with the estimate: 75%; the middle value does not contradict the limit.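

Among the compounds shown here, compound 1 and compound 3 both stand only as limits in this assay, so no step between them can be read: the limit of > 10000 nM in this assay, at which 3 of the 3 values shown sit. The compounds shown leave open what chloro in place of hydrogen on an aromatic carbon does to the inhibition constant, and where any compound of the series would give a number in this assay.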